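The source may report more compounds than this note shows. Statements on the series, on what has been measured and on what is new or still open speak of the compounds shown alone.

Measured so far:
- Compound 1, `O=C(Nc1ccc(Oc2ccnc3[nH]ccc23)cc1)c1nccc(-c2cccc(Cl)c2)n1`: 10200 nM
- Compound 2, `COc1ccc(-c2cc(C(=O)Nc3ccc(Oc4ccnc5[nH]ccc45)cc3)ncn2)cc1`: 4450 nM
- Compound 3, `COc1ccc(-c2cc(C(=O)Nc3ccc(Oc4ccnc5[nH]ccc45)c(F)c3)ncn2)cc1`: 10400 nM

All three were tested in a functional assay on MCF7 cells (Homo sapiens) for cytotoxicity, read by MTT assay, with a stated time of 72 h; a lower number here means a stronger inhibitor, a higher number a weaker inhibitor. Compound 3 gives the largest of the three numbers, but its value and that of compound 1 lie within the usual scatter of each other, so no order between them can be read. Within the data shown here, the one step that stands beyond the scatter is a 2.3-fold higher number from compound 2 to compound 3 (0.37 log units; beyond the scatter), where the only change is fluoro in place of hydrogen on an aromatic carbon.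

Compound 4, `O=C(Nc1ccc(Oc2ccnc3[nH]ccc23)c(F)c1)c1cc(-c2ccc(Br)cc2)ncn1`, keeps that fluoro and differs from compound 3 in one other place: bromo in place of methoxy on an aromatic carbon. Among the measured compounds shown here, no measured pair among the three compounds changes this position, so nothing here tells how a bromo against a methoxy at this place moves the number. For the measured compounds named here, with no step to lean on, the expectation for compound 4 in this assay is a change of about a 1.0-fold lower number from compound 3 to compound 4 (0.02 log units; within the scatter) from compound 3, that is, none beyond the scatter. Compound 4 is therefore estimated at 10000 nM, with a range from 4000 nM to 25000 nM.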

Compound 4, half-maximal inhibitory concentration: 10300 nM
Beside the measured number, compound 4's estimate is 1.0-fold (0.01 log units) below it; the range from low to high includes it.
By their numbers in this assay, from the lowest: compound 2; then compounds 1, 4 and 3 (each within the scatter of the next).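

In this assay, 4-bromophenyl in place of 4-methoxyphenyl gives a 1.0-fold lower number from compound 3 to compound 4 (0.00 log units; within the scatter) and so leaves the number where it was, which means that, with the fluoro in place, the two groups cannot be told apart at this position. This is the first measured pair among the compounds shown that changes this position, and it shows that losing the methoxy, with its one hydrogen-bond acceptor, does not by itself shift the reading. Nothing measured here offers a reason for this result.

It remains open whether bromo and methoxy would also match without the fluoro, as in the setting of compound 2, whose number is the lowest shown. From the compounds shown here alone, it is also open whether a different group at this place, such as an amine, a carboxylic acid or a longer chain, would move the number at all.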